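A few compounds are considered here, and "the series" means these few. Any claim that something is new, unique, unknown or untested is made for them only; others in the source may bear on it.

Measured compounds:
Compound 1 `CC1(C[C@@H](O)C(=O)N2N=CC[C@H]2C(=O)NCc2cc(Cl)ccc2-n2cnnn2)CC1`: 9.5 10^-6 cm/s
Compound 2 `CC(C)(C)C[C@@H](O)C(=O)N1CC[C@@H]2C[C@@]21C(=O)NCc1cc(Cl)ccc1-n1cnnn1`: 7.8 10^-6 cm/s
Compound 3 `O=C(NCc1cc(Cl)ccc1-n1cnnn1)[C@@H]1C[C@@H]2C[C@@H]2N1C(=O)[C@H](O)Cn1cccn1`: 0.45 10^-6 cm/s

All three were run in an ADME assay on Caco-2 cells (Homo sapiens) for permeability, read by LC-MS, in the apical to basolateral direction, with a stated time of 60 min, at pH 6.5; a lower number here means that the compound crosses the layer more slowly, a higher number that the compound crosses the layer faster. Compound 1 and compound 2 give numbers that lie within the usual scatter of each other, so no order can be read between them. Compound 3 gives a number far lower than compound 1, a gap well beyond the scatter. Compound 4 `O=C(NCc1cc(Cl)ccc1-n1cnnn1)[C@@H]1CC=NN1C(=O)[C@H](O)Cc1ccccc1` has not yet been measured. Its difference from compound 1 is phenyl in place of 1-methylcyclopropyl on a saturated chain carbon, two bonds along the chain from a carbonyl carbon and an oxygen on a saturated carbon. For the measured compounds named here, no measured pair shows this change, so there is no direct guide to its effect. The expected step is small, within the scatter, in either direction: a 1.2-fold lower number from compound 1 to compound 4 (0.07 log units; within the scatter). On that basis compound 4 is estimated to give 8 10^-6 cm/s, most likely between 3 10^-6 cm/s and 20 10^-6 cm/s.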

Compound 4, apparent permeability: 11 10^-6 cm/s
The estimate for compound 4 lay 1.4-fold (0.14 log units) below the measured number; the measured number falls inside the stated range.
By their numbers in this assay, from the lowest: compound 3; then compounds 2, 1 and 4 (each within the scatter of the next).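

In this assay, phenyl in place of 1-methylcyclopropyl on this saturated chain carbon gives a 1.2-fold higher number from compound 1 to compound 4 (0.06 log units; within the scatter), so this swap of a three-membered non-aromatic ring for a six-membered aromatic ring leaves the number unchanged within the scatter. For the compounds shown here, this is the first single-place comparison at this position, and it covers only these two carbon-only groups. Nothing measured here offers an explanation for this result. Going by these compounds, whether an amine or a carboxylic acid at this place would leave the number similarly unchanged remains open. On these data alone, whether phenyl would do the same on the core of compound 2 also remains open.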